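The source may report more compounds than this note shows. Statements on the series, on what has been measured and on what is new or still open speak of the compounds shown alone.

Compound 1 `CS(=O)(=O)c1ccc(C(=O)N2CCC(C(=O)N3CCc4ccccc43)CC2)cc1[N+](=O)[O-]` — > 60000 nM
Compound 2 `CN(Cc1ccccc1F)C(=O)CNC(=O)c1ccc(S(C)(=O)=O)c([N+](=O)[O-])c1` — 24000 nM
Compound 3 `CN(CC(=O)N1CCN(c2ccc(F)cc2)CC1)C(=O)c1ccc(S(C)(=O)=O)c([N+](=O)[O-])c1` — > 60000 nM

All three were tested in an assay on isolated protein for inhibition of thyroid hormone receptor beta (Homo sapiens), read by fluorescence polarization; a lower number here means a stronger inhibitor, a higher number a weaker inhibitor. Compound 1 did not reach a number in this assay: its value of > 60000 nM is a limit, the highest concentration tested, and no inhibition was found there. Compound 3 likewise sits at a limit, > 60000 nM. Only compound 2 gives a real number, 24000 nM, which still means a weak inhibitor. So compound 1 stands at the limit of > 60000 nM in this assay, at which 2 of the 3 values shown sit, and nothing measured so far separates it from compound 3.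

Compound 4 `CC(C)N(C(=O)C1CCN(C(=O)c2ccc(S(C)(=O)=O)c([N+](=O)[O-])c2)CC1)C(C)C` has not yet been measured. It keeps the core of compound 1 and changes one group: diisopropylamino in place of 2,3-dihydro-1H-indol-1-yl on a carbonyl carbon. No step between two measured compounds shows what such an exchange does, so the expectation rests on the fact that two of the three compounds shown, including compound 1, gave only a limit in this assay.

Compound 4 is therefore expected to stay weak, most likely again at the limit, with an estimated value of 60000 nM in a range from 20000 nM to 200000 nM, which is the step of a number no higher from compound 1 to compound 4 (the limit leaves the size open) expected, none beyond the scatter.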

Compound 4, half-maximal inhibitory concentration: > 60000 nM
Compound 4 was reported as a limit; the forecaster's own chance of this, stated with the estimate: 70%; the middle value sits exactly at the limit.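

In this assay, on these data alone, compound 4 and compound 1 both end at a limit, so no step can be read between them, and the size of the exchange stays unknown. The picture of the series stays the same: the limit of > 60000 nM in this assay, at which 3 of the 4 values shown sit. The compounds shown leave open whether any group on that carbonyl carbon could bring the core of compound 1 to a measurable value.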